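Acetyl for nitro on two differently joined cores

A few compounds are considered here, and "the series" means these few. Any claim that something is new, unique, unknown or untested is made for them only; others in the source may bear on it.

Compound 1 `COC1Cc2c(csc2-c2ccc([N+](=O)[O-])cc2)C2(CCN(Cc3ccccc3)CC2)O1` and compound 3 `COC1Cc2cc(-c3ccc([N+](=O)[O-])cc3)sc2C2(CCN(Cc3ccccc3)CC2)O1` contain the same atoms joined differently; the difference between the two cores is not broken down here. In an assay on membranes from brain for displacement of a labelled ligand from Sigma non-opioid intracellular receptor 1 (Cavia porcellus), read by scintillation counting, with a stated time of 120 min (on this read-out lower numbers stand for stronger inhibition and higher numbers for weaker inhibition), compound 1 gives 1 nM, whereas compound 3 gives 16 nM. Compound 2 `COC1Cc2c(csc2-c2ccc(C(C)=O)cc2)C2(CCN(Cc3ccccc3)CC2)O1` carries the change acetyl in place of nitro on an aromatic carbon on the core of compound 1; in this assay compound 2 gives 1.6 nM, which is a 1.6-fold higher number from compound 1 to compound 2 (0.20 log units; within the scatter). Compound 4 `COC1Cc2cc(-c3ccc(C(C)=O)cc3)sc2C2(CCN(Cc3ccccc3)CC2)O1`, still unmeasured, carries the same change acetyl in place of nitro on an aromatic carbon on the core of compound 3, at an identical place. Because that change earlier produced a 1.6-fold higher number from compound 1 to compound 2 (0.20 log units; within the scatter), the expectation is a 1.6-fold higher number from compound 3 to compound 4 (0.19 log units; within the scatter). Compound 4 is accordingly estimated at 25 nM in this assay, with a plausible range from 10 nM to 60 nM.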

Compound 4, inhibition constant: 59 nM
For compound 4 the middle estimate is 2.4-fold (0.37 log units) below the measured one; measured number inside the range.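

In this assay, acetyl in place of nitro on the core of compound 3 gives a 3.7-fold higher number from compound 3 to compound 4 (0.57 log units; beyond the scatter), while on the core of compound 1 it gives a 1.6-fold higher number from compound 1 to compound 2 (0.20 log units; within the scatter). Among the compounds shown here, only one of these steps lies beyond the scatter, yet the two do not differ from each other beyond what repeated measurement allows: the same change on two cores in this assay, a 1.6-fold higher number (0.20 log units; within the scatter) from compound 1 to compound 2 and a 3.7-fold higher number (0.57 log units; beyond the scatter) from compound 3 to compound 4, 2.3-fold (0.36 log units) apart, within the scatter of two such steps. The change therefore carries across these two cores with no demonstrated dependence on the core, but a single pair on each core does not show that the cores respond alike, nor does it explain either step.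

As far as these compounds go, it remains open whether a nitrile or an amine on the same aromatic carbon, para to a large group, would behave comparably on both cores.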